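A few compounds are considered here, and "the series" means these few. Any claim that something is new, unique, unknown or untested is made for them only; others in the source may bear on it.

Compound 1, `NC(=O)c1c(NC(=O)c2ccccc2Cl)sc2c1CCN(Cc1c(Cl)cccc1Cl)C2`: in a functional assay on HeLa cells (Homo sapiens) for antiproliferative activity, with a stated time of 24 h (on this read-out lower numbers stand for stronger inhibition and higher numbers for weaker inhibition), compound 1 gives 28800 nM.
Compound 2, `NC(=O)c1c(NC(=O)c2ccc(C(F)(F)F)cc2)sc2c1CCN(Cc1c(Cl)cccc1Cl)C2`: in this assay compound 2 gives only a limit of the assay, > 50000 nM.
Compound 3, `Cc1ccc(C(=O)Nc2sc3c(c2C(N)=O)CCN(Cc2c(Cl)cccc2Cl)C3)cc1`: in this assay compound 3 gives 47400 nM.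

Compound 3 carries the highest of the two numbers; the gap from compound 1 is a 1.6-fold higher number from compound 1 to compound 3 (0.22 log units; within the scatter). Against the limit of compound 2 the gap is an at least 1.0-fold lower number from compound 2 to compound 3 (0.02 log units; that floor lies within the scatter). Compound 4, `Cc1ccc(C(=O)Nc2sc3c(c2C(N)=O)CCN(C(=O)Nc2ccccc2Cl)C3)cc1`, differs from compound 3 in one place: (2-chlorophenyl)carbamoyl in place of 2,6-dichlorobenzyl on an amine nitrogen in a ring. All three measured steps, an at least 1.7-fold higher number from compound 1 to compound 2 (0.23 log units; that floor lies within the scatter), a 1.6-fold higher number from compound 1 to compound 3 (0.22 log units; within the scatter) and an at least 1.0-fold lower number from compound 2 to compound 3 (0.02 log units; that floor lies within the scatter), exchange the aryl group on the carbonyl carbon and leave the amine nitrogen in the ring untouched, so none of them speaks to this change. What is known is that every exchange tried so far stayed within the scatter and that all values remain weak. The expected outcome is therefore a step of a 1.1-fold lower number from compound 3 to compound 4 (0.02 log units; within the scatter) in this assay, with a wide range in either direction. For compound 4 the estimated value in this assay is 45000 nM, between 12000 nM and 150000 nM.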

Compound 4, half-maximal inhibitory concentration: 32900 nM
Beside the measured number, compound 4's estimate is 1.4-fold (0.14 log units) above it, and the stated range covers the measured number.
By their numbers in this assay, from the lowest: compounds 1, 4 and 3 (each within the scatter of the next). At a limit, above all of these: compound 2.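

Among the compounds shown, only this step alters the amine nitrogen in a ring, and in this assay it is a 1.4-fold lower number from compound 3 to compound 4 (0.16 log units; within the scatter). So (2-chlorophenyl)carbamoyl can take the place of 2,6-dichlorobenzyl on this nitrogen with no readable change, although only the entering group has a hydrogen-bond donor and acceptor. This rests on a single pair of compounds, and the read-out offers little room to show a further loss of activity: the limit of > 50000 nM in this assay, at which 1 of the 4 values shown sits.

The compounds shown leave open whether a group without an aromatic ring on this nitrogen, such as a longer alkyl chain, a chain ending in an amine or one ending in a carboxylic acid, would move the number beyond the scatter. They also leave open whether this exchange gives the same result with an aryl group other than 4-methylphenyl on the carbonyl carbon.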